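Swapping a carboxy-bearing amine for a plain hydroxy

This account rests on a few compounds, and the source may have more. Where it says the series, first, only, none or still open, it means among the compounds named here.

Compound 1 (`COc1ccc(/C=C\c2cc(OC)c(OC)c(OC)c2)cc1OCc1ccc(CN2CCCCC2C(=O)O)cc1`) and compound 2 (`COc1ccc(/C=C\c2cc(OC)c(OC)c(OC)c2)cc1OCc1ccc(CN[C@H](C(=O)O)[C@H](C)O)cc1`) share one core and differ in the group on a saturated chain carbon bound to an aromatic carbon. In a functional assay on MC-38 cells (Mus musculus) for antiproliferative activity, read by CCK-8 assay, with a stated time of 48 h (a lower number here means a stronger inhibitor, a higher number a weaker inhibitor), compound 1 gives 5400 nM as its reading. Compound 2 gives > 10000 nM as its reading, and this is a limit of the assay and not a number. Going by the values given here, the only measured step is an at least 1.8-fold higher number from compound 1 to compound 2 (0.26 log units; that floor lies within the scatter) and it exchanges one carboxy-bearing amine for another. Compound 3 (`COc1ccc(/C=C\c2cc(OC)c(OC)c(OC)c2)cc1OCc1ccc(CO)cc1`) departs further, with hydroxy in place of (1-carboxy-2-hydroxypropyl)amino at that same carbon (hydroxy in place of (1-carboxy-2-hydroxypropyl)amino on a saturated chain carbon bound to an aromatic carbon). Among the compounds with values here, no measured step covers the loss of the whole amine, so the size of the change is a judgement. Within the data shown here, with compound 1 at 5400 nM as the only real number for such a group, a clearly lower number is expected in this assay once the group is gone. The expected change is an at least 25-fold lower number from compound 2 to compound 3 (1.39 log units; beyond the scatter) in this estimate. Compound 3 is estimated at 400 nM as a middle value, with an expected range from 40 nM to 4000 nM for the measurement.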

Compound 3, half-maximal inhibitory concentration: 5700 nM
For compound 3 the middle estimate is 14-fold (1.15 log units) below the measured one; the measured number lies above the stated range.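

Exchanging 2-carboxypiperidin-1-yl for hydroxy on a saturated chain carbon bound to an aromatic carbon gives a 1.1-fold higher number from compound 1 to compound 3 (0.02 log units; within the scatter) in this assay, so the two groups cannot be told apart here, and losing the whole amine does not by itself change the reading. Exchanging (1-carboxy-2-hydroxypropyl)amino for hydroxy at the same carbon gives an at least 1.7-fold lower number from compound 2 to compound 3 (0.24 log units; that floor lies within the scatter), and this floor alone shows no real change. Compound 2 gives > 10000 nM, which is a limit of the assay and not a number, so its true distance from the other compounds cannot be read: the limit of > 10000 nM in this assay, at which 1 of the 3 values shown sits.

The compounds shown leave open how an amine without a carboxy group, or a carboxylic acid with no amine, would read at this carbon. They also leave open whether a reading of this size depends on the group at this carbon at all or rests on the shared core.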